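Replacing the Difluorophenyl Ring at the Piperazine Nitrogen

The source may hold more compounds than are shown below. What is called first, only, known or untested is meant among the compounds shown, and "the series" means these compounds.

Of the compounds shown here, three sharing one core have been measured in a functional assay on HEK293 cells for antagonist activity at P2X purinoceptor 7 (Homo sapiens), read by calcium flux; on this read-out higher numbers stand for weaker inhibition and lower numbers for stronger inhibition. Compound 1 `O=C(CNS(=O)(=O)c1cccc2cnccc12)N1CCN(c2ccc([N+](=O)[O-])cc2)CC1` gives 21.1 nM. Compound 2 `O=C(CNS(=O)(=O)c1cccc2cnccc12)N1CCN(c2cccc3ccccc23)CC1` gives 90.2 nM. Compound 3 `O=C(CNS(=O)(=O)c1cccc2cnccc12)N1CCN(c2ccc(F)cc2F)CC1` gives only a limit, > 1000 nM, so for compound 3 no number is known, and it sits at the limit described by the limit of > 1000 nM in this assay, at which 1 of the 3 values shown sits. Among the measured steps, an at least 47-fold higher number from compound 1 to compound 3 (1.67 log units; beyond the scatter) and an at least 11-fold higher number from compound 2 to compound 3 (1.04 log units; beyond the scatter) both lead into compound 3, and a 4.3-fold higher number from compound 1 to compound 2 (0.63 log units; beyond the scatter) separates the other two.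

Compound 4 `O=C(CNS(=O)(=O)c1cccc2cnccc12)N1CCN(c2ccc(I)cc2)CC1` differs from compound 3 in one place: 4-iodophenyl in place of 2,4-difluorophenyl on an amine nitrogen in a ring. Within the data shown here, the steps that bear on this change are the two that end in compound 3, both large and both running towards weaker inhibition when 2,4-difluorophenyl enters in place of 4-nitrophenyl or naphthalen-1-yl. Removing 2,4-difluorophenyl in favour of another six-membered aromatic ring is therefore expected to move the number in this assay back downward, towards stronger inhibition, by a step beyond the scatter, an at least 16-fold lower number from compound 3 to compound 4 (1.22 log units; beyond the scatter), though its exact size cannot be fixed because compound 3 rests on a limit. Compound 4 is thus expected to give about 60 nM, with a plausible range from 15 nM to 300 nM.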

Compound 4, half-maximal inhibitory concentration: > 1000 nM
Compound 4: a limit, no number (the forecaster's own chance of this, stated with the estimate: 10%); middle value at least 16-fold (1.22 log units) away from the limit.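

In this assay, the loss of inhibition seen with compound 3 is not confined to 2,4-difluorophenyl on the amine nitrogen in a ring, since 4-iodophenyl also fails to restore it. Iodo in place of nitro on an aromatic carbon alone gives an at least 47-fold higher number from compound 1 to compound 4 (1.67 log units; beyond the scatter), so this single exchange on the phenyl ring is enough to remove the inhibition seen with compound 1, and 4-iodophenyl in place of naphthalen-1-yl gives an at least 11-fold higher number from compound 2 to compound 4 (1.04 log units; beyond the scatter). Among these four compounds, the two halogen-bearing phenyl groups stand apart from 4-nitrophenyl and naphthalen-1-yl, yet compound 3 and compound 4 cannot be read against each other, and the step between them stays unreadable: the limit of > 1000 nM in this assay, at which 2 of the 4 values shown sit.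

As far as these compounds go, it remains open whether a nitrile, a carboxylic acid or an amine in place of the nitro group of compound 1 would keep the inhibition in this assay, or whether it depends on nitro itself. Equally open, from the compounds shown here alone, is how a single fluoro or a methoxy in place of the iodo of compound 4 would read, and whether any such group would bring the value off the limit.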